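Acetyl to cyano: from compound 3 to compound 4

The source may hold more compounds than are shown below. What is called first, only, known or untested is meant among the compounds shown, and "the series" means these compounds.

Compound 1 `C=C(CC)C(=O)c1ccc(OCC(=O)Nc2ccc(S(=O)(=O)O)cc2)c(Cl)c1Cl`: > 25000 nM, a limit of the assay
Compound 2 `C=C(CC)C(=O)c1ccc(OCC(=O)Nc2ccc(/C=C/C(=O)NO)cc2)c(Cl)c1Cl`: 2600 nM
Compound 3 `C=C(CC)C(=O)c1ccc(OCC(=O)Nc2ccc(C(C)=O)cc2)c(Cl)c1Cl`: 3900 nM

All three were tested in a functional assay on CLL cells (Homo sapiens) for cytotoxicity, read by MTT assay, with a stated time of 48 h; a higher number here means that more compound is needed for the effect, a lower number that less compound is needed. Going by the values given here, compound 3 stands level with the only other exact number, since a 1.5-fold higher number from compound 2 to compound 3 (0.18 log units; within the scatter). Removing sulfo gave the two larger steps, an at least 9.6-fold lower number from compound 1 to compound 2 (0.98 log units; beyond the scatter) and an at least 6.4-fold lower number from compound 1 to compound 3 (0.80 log units; beyond the scatter), both measured from a limit.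

Compound 4 `C=C(CC)C(=O)c1ccc(OCC(=O)Nc2ccc(C#N)cc2)c(Cl)c1Cl` arises through cyano in place of acetyl on an aromatic carbon, para to a large group. Among the compounds with values here, no measured step makes this exact exchange. The closest guide is the exchange of acetyl for a different group, a 1.5-fold higher number from compound 2 to compound 3 (0.18 log units; within the scatter). The step expected in this assay is therefore a 1.1-fold lower number from compound 3 to compound 4 (0.05 log units; within the scatter), with no change beyond the scatter. Compound 4 is estimated at 3500 nM, with an expected range from 1500 nM to 8500 nM.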

Compound 4, half-maximal effective concentration: 7800 nM
Compound 4: the middle estimate sits 2.2-fold (0.35 log units) below what was measured; the range from low to high includes it.
By their numbers in this assay, from the lowest: compounds 2, 3 and 4 (each within the scatter of the next, the first and the last beyond it). At a limit, above all of these: compound 1.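

In this assay, the exchange at this aromatic carbon, para to a large group, gives a 2.0-fold higher number from compound 3 to compound 4 (0.30 log units; within the scatter), so 4-acetylphenyl and 4-cyanophenyl are not separated here. Cyano does separate from 2-(hydroxycarbamoyl)ethenyl, with a 3.0-fold higher number from compound 2 to compound 4 (0.48 log units; beyond the scatter), the only gap between exact numbers that lies beyond the scatter, although acetyl did not separate from that group. Against sulfo, cyano gives an at least 3.2-fold lower number from compound 1 to compound 4 (0.50 log units; beyond the scatter), a step measured from a limit: the limit of > 25000 nM in this assay, at which 1 of the 4 values shown sits.

The compounds shown leave open whether an amine or a carboxylic acid at this carbon would differ from acetyl and cyano beyond the scatter.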